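Demethylation of a flavonol: from compound 2 to compound 3

The compounds below may be only part of what the source reports. "The series", "measured", "known", "first", "only" and "open" are said of these compounds alone.

Of the compounds shown here, two have been measured in a functional assay on cells (Platelet, Oryctolagus cuniculus) for inhibition, read by turbidimetry, with a stated time of 3 min, tested at 100 ug/mL; a higher number here means a weaker effect of the compound at the concentration tested, a lower number a stronger effect. Compound 1 `CC/C=C/C/C=C\CC/C=C/C=C/C(=O)NCC(C)(C)O` gives 0% in this assay. Compound 2 `COc1ccc(-c2oc3c(OC)c(OC)cc(O)c3c(=O)c2O)cc1` gives 73.3% in this assay, the higher of the two numbers, and the gap to compound 1 lies beyond the scatter of repeated measurements.

Compound 3 `COc1ccc(-c2oc3c(OC)c(O)cc(O)c3c(=O)c2O)cc1` has not yet been measured in this assay. It differs from compound 2 in one place: hydrogen in place of methyl on an oxygen on an aromatic ring. Cut one bond further out, the change reads methoxy to hydroxy.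

Among the measured compounds shown here, no step between two measured compounds speaks to this change, so the expectation rests on compound 2 alone. A step of modest size is expected, in the direction of a somewhat lower number, though a result within the scatter of compound 2 would not surprise, as the estimated step of a number 8.3 percentage points lower from compound 2 to compound 3 (within the scatter) shows. For compound 3 the expected value in this assay is 65%, within a range from 40% to 90%.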

Compound 3, a percentage reported as activity, at one concentration (the size of the read-out at that concentration, not a potency): 0%
For compound 3 the middle estimate is 65 percentage points above the measured one, outside the stated range (below it).
By their numbers in this assay, from the lowest: compounds 1 and 3 (each within the scatter of the next); then compound 2.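

In this assay, where a lower number means a stronger effect at the concentration tested, the change from methoxy to hydroxy gives a large step, a number 73.3 percentage points lower from compound 2 to compound 3 (beyond the scatter). Among the compounds shown here, this is the first step between two measured compounds that differ in one place, and it shows that the read-out of the shared core depends strongly on whether this oxygen on the aromatic ring carries methyl or hydrogen. Nothing measured on these compounds accounts for the size of this step.

Going by these compounds, the other methoxy groups of compound 3 remain in place, so whether the same change at either of them gives a step of similar size stays open. Also open, on these data alone, is what an amine, or an ethoxy group, would give in place of this hydroxy.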